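The source may report more compounds than this note shows. Statements on the series, on what has been measured and on what is new or still open speak of the compounds shown alone.

Measured compounds:
- compound 1 `COc1ccc(C(C)NC(=O)/N=C(\N)NCCCc2sc(N)nc2C)cc1` — 38 nM
- compound 2 `Cc1nc(N)sc1CCCN/C(N)=N/C(=O)N[C@H](C)c1ccccc1` — 7.59 nM

Compound 1 and compound 2 were both tested in a functional assay on Right cardiac atrium for agonist activity at histamine H2 receptor (Cavia porcellus), with a stated time of 30 min, in the presence of a further agent that is not named here; on this read-out lower numbers stand for an effect already at smaller amounts and higher numbers for an effect only at larger amounts of compound. Of the two, compound 1 gives the higher number with 38 nM, while compound 2 with 7.59 nM stands at a lower number, and the gap between the two lies beyond the usual scatter of this assay. Compound 1 therefore sits at the upper end of what has been measured so far.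

The step under consideration leads from compound 1 to compound 3 `Cc1nc(N)sc1CCCN/C(N)=N/C(=O)NC(C)c1ccc(Br)cc1`. The change is bromo in place of methoxy on an aromatic carbon, para to a large group, so that a 4-methoxyphenyl becomes a 4-bromophenyl. Everything else in the molecule is kept.

Going by the values given here, no measured pair shows this particular exchange, so the size of the step rests on judgement alone. Compound 3 is expected to come out close to compound 1, with a step of a 1.5-fold lower number from compound 1 to compound 3 (0.18 log units; within the scatter) that probably stays within the scatter, perhaps leaning toward a slightly lower number. The estimate for compound 3 in this assay is 25 nM, with a likely range from 8 nM to 80 nM.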

Compound 3, half-maximal effective concentration: 55 nM
Estimate against measurement, compound 3: 2.2-fold (0.34 log units) below; the range from low to high includes it.
By their numbers in this assay, from the lowest: compound 2; then compounds 1 and 3 (each within the scatter of the next).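

In this assay, this position now has its first measured exchange, the step of a 1.4-fold higher number from compound 1 to compound 3 (0.16 log units; within the scatter), so 4-methoxyphenyl and 4-bromophenyl cannot be told apart on this read-out. Methoxy brings two heavy atoms and one hydrogen-bond acceptor and bromo one heavy atom and no acceptor, so on an aromatic carbon para to a large group, this difference in counts goes with no step beyond the scatter in this single pair. No measurement shown here explains this outcome, and the pair alone gives no reason for it.

What the compounds shown leave open is whether an amine, a carboxylic acid or a longer chain such as n-butoxy in this same place would also stay within the scatter of compound 1, or would give a step beyond it. They also leave open whether bromo in place of methoxy would read the same way on a core that differs from that of compound 1.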